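A Chloro for Fluoro Swap Carried to a Second Core

The compounds below may be only part of what the source reports. "The series", "measured", "known", "first", "only" and "open" are said of these compounds alone.

Of the compounds shown here, three have so far been measured in an assay on U2OS cells for activation of nuclear factor erythroid 2-related factor 2 (Homo sapiens), read by beta-arrestin recruitment, with a stated time of 6 h; a higher number here means that more compound is needed for the effect, a lower number that less compound is needed. Compound 1 `O=S(=O)(/C=C/c1ncccc1F)c1ccccc1F` gives 176 nM. Compound 3 `O=S(=O)(/C=C/c1ncccc1F)c1ccccc1Cl` differs from it by chloro in place of fluoro on an aromatic carbon and gives 122 nM; the step is a 1.4-fold lower number from compound 1 to compound 3 (0.16 log units; within the scatter). Compound 2 `O=S(=O)(/C=C/c1ccccn1)c1cccc(F)c1` gives 1680 nM, the highest of the three numbers, and its nearest neighbour among them is compound 1. The difference between the core of compound 2 and the core of compound 1 is not broken down here.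

Compound 4 `O=S(=O)(/C=C/c1ccccn1)c1cccc(Cl)c1` has not yet been measured in this assay. It differs from compound 2 by chloro in place of fluoro on an aromatic carbon. Within the data shown here, this is the same kind of change as the one made between compound 1 and compound 3, though not the same: in compound 3 the chloro sits ortho to a large group, whereas in compound 4 it sits meta to a large group. The change has been seen only once among the measured compounds.

For this assay the step from compound 2 to compound 4 is expected to be a 1.3-fold lower number from compound 2 to compound 4 (0.11 log units; within the scatter), a small one, and this expectation rests on the earlier step of the same kind, a 1.4-fold lower number from compound 1 to compound 3 (0.16 log units; within the scatter), having stayed within the scatter. Compound 4 is therefore estimated at 1300 nM, with a likely range from 600 nM to 3000 nM.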

Compound 4, half-maximal effective concentration: 1430 nM
The estimate for compound 4 lay 1.1-fold (0.04 log units) below the measured number, and the stated range covers the measured number.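

On the second core, in this assay, chloro in place of fluoro on an aromatic carbon gives a 1.2-fold lower number from compound 2 to compound 4 (0.07 log units; within the scatter), and so this step, like the earlier one, stays within the scatter. Set side by side, the two steps do not differ: the same change on two cores in this assay, a 1.4-fold lower number (0.16 log units; within the scatter) from compound 1 to compound 3 and a 1.2-fold lower number (0.07 log units; within the scatter) from compound 2 to compound 4, 1.2-fold (0.09 log units) apart, within the scatter of two such steps. Among these compounds, this shows that, across these two pairs, the swap carried from one core to the other as a change too small to read, but it does not show that a small step would follow on any further core, since only two pairs are at hand, the halogen stands in a different place in each, and steps within the scatter cannot reveal a small real effect of the change.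

What the compounds shown leave open is how other groups would behave on the six-membered aromatic ring of carbon only, since bromo, methyl, methoxy and nitrile all lie outside the fluoro and chloro seen here. From the compounds shown here alone, it also remains open whether an amine or a carboxylic acid in that place would give a step beyond the scatter, and whether such a step would carry from one core to the other.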